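A Methyl Group Added to Compound 2

The compounds below may be only part of what the source reports. "The series", "measured", "known", "first", "only" and "open" are said of these compounds alone.

In a functional assay on 786-0 cells (Homo sapiens) for inhibition, read by sulforhodamine B assay, with a stated time of 48 h (on this read-out higher numbers stand for weaker inhibition of growth and lower numbers for stronger inhibition of growth), compound 1 (`CC(C)(C)NCc1c(C(=O)O)nn(-c2ccccc2)c1-c1ccc(F)cc1`) gives > 680000 nM as its result, which is a limit and not a number. Compound 2 (`CC(C)(C)NCc1c(C(=O)O)nn(-c2ccccc2)c1-c1ccccc1`) gives > 716000 nM as its result, which is also a limit. Within the data shown here, compound 2 therefore holds no numerical place, and the only other value shown is likewise a limit. Among the measured compounds shown here, the one measured step is a step that the two limits leave unreadable from compound 1 to compound 2 with hydrogen in place of fluoro on an aromatic carbon, so it supplies no size to carry forward. Compound 3 (`Cc1ccc(-c2c(CNC(C)(C)C)c(C(=O)O)nn2-c2ccccc2)cc1`) differs from compound 2 by methyl in place of hydrogen on an aromatic carbon with methyl in place of hydrogen on an aromatic carbon. In this assay the expected change is none beyond the scatter, and another limit is the likeliest report. The estimated step is an at least 1.0-fold lower number from compound 2 to compound 3 (0.01 log units; that floor lies within the scatter) in this account. For compound 3 the estimate is 688000 nM with an expected range from 300000 nM to 800000 nM for the measurement.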

Compound 3, concentration for 50% growth inhibition: > 688000 nM
Compound 3: no number, only a limit (the forecaster's own chance of this, stated with the estimate: 85%); the middle value sits exactly at the limit.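

In this assay, among these compounds, compound 1, compound 2 and compound 3 each give only a limit, so no step among them can be read. The compounds shown leave open how strongly any of them inhibits growth, and whether phenyl to 4-methylphenyl changes that at all.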